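Switching a Hydrazide Ether for a Propanoate Ester

The source may report more compounds than this note shows. Statements on the series, on what has been measured and on what is new or still open speak of the compounds shown alone.

This series shares a core in which a six-membered aromatic ring with one nitrogen carries a large fused bicyclic group and a second substituent. The read-out is an assay on a protein complex for inhibition of CDK8/Cyclin C (Homo sapiens), with a stated time of 1 h; on this read-out higher numbers stand for weaker inhibition and lower numbers for stronger inhibition. Compound 1 `CNC(=O)/C=C/c1ccncc1-c1ccc2cccnc2c1` gives 1760 nM, and compound 3 `CNC(=O)/C=C/c1ccncc1-c1ccc2c(cnn2C)c1` gives 86.7 nM. Compound 2 `NNC(=O)COc1ccncc1-c1ccc2ccccc2c1`, which carries an (aminocarbamoyl)methoxy group, stands in this assay as "not determined" (no result reported), so it cannot be placed on the scale at all.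

Compound 4 `COC(=O)CCc1ccncc1-c1ccc2ccccc2c1` keeps everything in compound 2 except that substituent, where the change is 2-(methoxycarbonyl)ethyl in place of (aminocarbamoyl)methoxy on an aromatic carbon. The new group sits on an aromatic carbon of the six-membered ring with one nitrogen, ortho to a large group and opposite the ring nitrogen.

Among the measured compounds shown here, with no number for compound 2 and no measured pair showing this exchange, the size and direction of the step cannot be taken from the data; the two propenamide compounds only mark out where this kind of core has landed so far. Compound 4 is therefore expected to give roughly 2500 nM, with a wide range from 300 nM to 20000 nM.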

Compound 4, half-maximal inhibitory concentration: 259 nM
Estimate against measurement, compound 4: 9.7-fold (0.98 log units) above; measured number outside the range, below it.
By their numbers in this assay, from the lowest: compound 3; then compound 4; then compound 1.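

No step can be read between compound 2 and compound 4: in this assay compound 2 has no number and compound 4 gives 259 nM. As far as these compounds go, what exchanging (aminocarbamoyl)methoxy for 2-(methoxycarbonyl)ethyl does to inhibition stays open. Nothing available here accounts for the value of compound 4.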